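A Fluoropiperidinyl Swap on a Benzyloxybenzamide Series

This account rests on a few compounds, and the source may have more. Where it says the series, first, only, none or still open, it means among the compounds named here.

Two benzyloxybenzamides have been characterised in an assay on Sf9 cells for inhibition of Leucine-rich repeat serine/threonine-protein kinase 2 (Homo sapiens), read by TR-FRET, with stated times of 30 min and 2 h; a higher number here means a weaker inhibitor, a lower number a stronger inhibitor. Compound 1 `O=C(Nc1ccnnc1)c1cc(C(F)(F)F)ccc1OCc1ccccc1` gives 15.9 nM in this assay, which is the lowest of the two numbers recorded. Compound 2 `O=C(Nc1cccc(F)c1)c1cc(C(F)(F)F)ccc1OCc1ccc(F)cc1` gives 31.6 nM in this assay, and the two values lie within the scatter of each other, so no order can be drawn between them. For the measured compounds named here, the two compounds differ in more than one place, so their pair yields no isolated step.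

Compound 3 `O=C(Nc1ccnnc1)c1cc(N2CCC(F)CC2)ccc1OCc1ccccc1` has not yet been measured. It differs from compound 1 by 4-fluoropiperidin-1-yl in place of trifluoromethyl on an aromatic carbon. Going by the values given here, no measured pair here isolates a change of this kind, so the expected size and direction of the step rest only on the starting value of compound 1.

With that in mind, the expected step from compound 1 to compound 3 in this assay is a 1.6-fold higher number from compound 1 to compound 3 (0.20 log units; within the scatter), with the possibility of a modest loss within a wider range. Compound 3 is therefore estimated to give 25 nM in this assay, with a range from 6 nM to 100 nM.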

Compound 3, half-maximal inhibitory concentration: 39.8 nM
For compound 3 the middle estimate is 1.6-fold (0.20 log units) below the measured one; the measured number falls inside the stated range.
By their numbers in this assay, from the lowest: compounds 1, 2 and 3 (each within the scatter of the next, the first and the last beyond it).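

For the compounds shown here, putting 4-fluoropiperidin-1-yl in place of trifluoromethyl, on the aromatic carbon meta to the (pyridazin-4-yl)carbamoyl group and para to the benzyloxy group, gives the first isolated step: in this assay the change amounts to a 2.5-fold higher number from compound 1 to compound 3 (0.40 log units; beyond the scatter), which is a modest loss. This position therefore tolerates a larger group carrying a six-membered non-aromatic ring, and compound 3 still gives 39.8 nM in this assay, so the trifluoromethyl group is not essential for measurable inhibition in this assay. No measurement available here bears on the reason for the step, which stands as an observation only.

With a single replacement at this position, the compounds shown leave open whether the loss follows from the ring, from its fluorine or from the nitrogen attached to the aromatic carbon. Going by these compounds, a plain piperidine, a morpholine, a dimethylamino group or a nitrile on the same carbon would help to separate these, and it also remains open whether the step would carry over to the core of compound 2.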